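The compounds below may be only part of what the source reports. "The series", "measured", "known", "first", "only" and "open" are said of these compounds alone.

Among the measured compounds shown here, in a functional assay on HeLa cells (Homo sapiens) for cytotoxicity, read by MTT assay (on this read-out lower numbers stand for stronger inhibition and higher numbers for weaker inhibition), compound 1 `CC(=O)OCCC(=O)O[C@H](CC=C(C)C)C1=CC(=O)c2c(O)ccc(O)c2C1=O` gives 17300 nM, while compound 2 `CCCCC(CC(=O)O[C@H](CC=C(C)C)C1=CC(=O)c2c(O)ccc(O)c2C1=O)OC(C)=O` gives 73500 nM, the higher of the two numbers so far. Compound 3 `CC(C)=CC[C@@H](OC(=O)CC(O)c1ccccc1)C1=CC(=O)c2c(O)ccc(O)c2C1=O` has not yet been measured. It differs from compound 2 by hydroxy(phenyl)methyl in place of 1-acetoxypentyl on a saturated chain carbon bound to a carbonyl carbon: hydroxy(phenyl)methyl stands in place of 1-acetoxypentyl on a saturated chain carbon bound to a carbonyl carbon. For the measured compounds named here, only one measured step bears on this change, a 4.2-fold higher number from compound 1 to compound 2 (0.63 log units; beyond the scatter), a modest rise beyond the scatter when butyl replaced hydrogen. Compound 3 no longer carries that butyl portion, but it brings a six-membered aromatic ring found in neither measured compound, so this single step is a weak guide. A modest move to a lower number is expected, described as a 2.9-fold lower number from compound 2 to compound 3 (0.47 log units; beyond the scatter). The estimated value for compound 3 is 25000 nM, with an expected range from 8000 nM to 75000 nM.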

Compound 3, half-maximal inhibitory concentration: 44500 nM
Beside the measured number, compound 3's estimate is 1.8-fold (0.25 log units) below it, within the range that was stated.
By their numbers in this assay, from the lowest: compound 1; then compounds 3 and 2 (each within the scatter of the next).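

In this assay, hydroxy(phenyl)methyl in place of 1-acetoxypentyl on a saturated chain carbon bound to a carbonyl carbon gives a 1.7-fold lower number from compound 2 to compound 3 (0.22 log units; within the scatter), so a six-membered aromatic ring of carbon only can stand at this place with no change that can be told from the scatter. Hydroxy(phenyl)methyl in place of acetoxymethyl gives a 2.6-fold higher number from compound 1 to compound 3 (0.41 log units; beyond the scatter), so compound 1 keeps a lower number than the other two, whether the group that replaces acetoxymethyl carries a ring or not. Nothing measured here offers a reason for these steps.

From the compounds shown here alone, the hydroxy group and the phenyl ring enter together, so what each contributes alone stays open. Going by these compounds, what an amine or a carboxylic acid at this place would do in this assay also remains open.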